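The source may report more compounds than this note shows. Statements on the series, on what has been measured and on what is new or still open speak of the compounds shown alone.

Among the measured compounds shown here, compound 2, `CCCCc1ccc(NC(=O)N[C@@H](C)c2ccccc2)cc1`, stands second highest of the three numbers so far in an ADME assay on the whole organism with Oryza sativa as the target, tested at 10 uM (on this read-out higher numbers stand for a weaker effect at the one concentration tested and lower numbers for a stronger effect), where compound 2 gives 60%. For the measured compounds named here, its mirror-image partner compound 1, `CCCCc1ccc(NC(=O)N[C@H](C)c2ccccc2)cc1`, gives 28%, and a number 32 percentage points higher from compound 1 to compound 2 (beyond the scatter); the only evidence on that step is the fact that compounds 1 and 2 differ only in the configuration as drawn. Compound 3, `CCOC(=O)c1cccc(NC(=O)N[C@@H](C)c2ccccc2)c1`, gives 96%. The next compound, compound 4, `C[C@H](NC(=O)Nc1ccc(F)cc1)c1ccccc1`, differs from compound 2 by fluoro in place of butyl on an aromatic carbon. Going by the values given here, no measured step concerns this change: the single step known, from compound 1 to compound 2, is a change of configuration only, and compound 3 differs from compound 2 in more than one place. Among the compounds with values here, the values of compound 2 and compound 3 show only that compound 2 sits lower. Compound 4 is therefore expected to give 75% in this assay, with a range from 50% to 95%, meaning an expected step of a number 15 percentage points higher from compound 2 to compound 4 (beyond the scatter).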

Compound 4, a percentage reported as activity, at one concentration (the size of the read-out at that concentration, not a potency): 85%
Beside the measured number, compound 4's estimate is 10 percentage points below it; measured number inside the range.
By their numbers in this assay, from the lowest: compound 1; then compound 2; then compound 4; then compound 3.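

Fluoro in place of butyl on an aromatic carbon, para to a large group, gives a number 25 percentage points higher from compound 2 to compound 4 (beyond the scatter) in this assay, so the group at this place on the shared core alters the read-out, here towards a weaker effect at the one concentration tested. Nothing given here bears on the reason for this step. From the compounds shown here alone, it remains open how a methyl, a longer chain, a chloro or a methoxy group would read at this place, and whether fluoro in place of butyl would give a similar step in the configuration of compound 1.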